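The source may hold more compounds than are shown below. What is called first, only, known or untested is meant among the compounds shown, and "the series" means these compounds.

Compound 1 `Cc1ccc(NC(=O)c2ccc(CN3CCCN(C)CC3)cc2)cc1-n1cc(-c2cnc3ccnn3c2)cn1` gives 20500 nM in an ADME assay on HEK-293T cells (Homo sapiens) for cytotoxicity, read by CCK-8 assay, with a stated time of 24 h; on this read-out lower numbers stand for higher toxicity in this test and higher numbers for lower toxicity in this test.
Compound 2 `Cc1ccc(NC(=O)c2ccc(C(F)(F)F)cc2)cc1-n1cc(-c2cnc3cccnn23)cn1` gives in this assay a value that is an assay limit, > 80000 nM.
Compound 3 `COc1ccc(C(=O)Nc2ccc(C)c(-n3cc(-c4cnc5ccnn5c4)cn3)c2)cc1` gives in this assay a value that is an assay limit, > 80000 nM.

Compound 3 thus stands at the top of what this assay reports: its reading is a limit and not a number, the limit at which two of the three measured values sit (the limit of > 80000 nM in this assay, at which 2 of the 3 values shown sit). For the measured compounds named here, the only measured step reaching compound 3 is an at least 3.9-fold higher number from compound 1 to compound 3 (0.59 log units; beyond the scatter), which carries compound 3 from a measured number into that limit.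

Compound 4 `Cc1ccc(NC(=O)c2ccc(C(F)(F)F)cc2)cc1-n1cc(-c2cnc3ccnn3c2)cn1` differs from compound 3 by trifluoromethyl in place of methoxy on an aromatic carbon. Going by the values given here, no measured pair spans this change directly. Compound 2, which carries the same 4-(trifluoromethyl)phenyl on a different core, also sits at the limit in this assay. On this basis the step is expected to stay within the scatter, as a step that the limit leaves unreadable from compound 3 to compound 4. Compound 4 is therefore expected to be reported again as a limit, estimated near 100000 nM with a range from 40000 nM to 300000 nM.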

Compound 4, half-maximal cytotoxic concentration: 43200 nM
Compound 4: middle estimate off by 2.3-fold (0.36 log units), on the high side; the measured number falls inside the stated range.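

With trifluoromethyl on this aromatic carbon of the shared core, compound 4 gives a measured number in this assay, where methoxy at the same place gave only a limit; the step is an at least 1.8-fold lower number from compound 3 to compound 4 (0.26 log units; that floor lies within the scatter), and the change of core alone gives an at least 1.8-fold lower number from compound 2 to compound 4 (0.26 log units; that floor lies within the scatter). Trifluoromethyl in place of the (4-methyl-1,4-diazepan-1-yl)methyl group still gives a 2.1-fold higher number from compound 1 to compound 4 (0.32 log units; beyond the scatter), so this change of group is the one step here with a size that can be read in full. The true size of the step from methoxy to trifluoromethyl cannot be told, because compound 3 is a limit and not a number: the limit of > 80000 nM in this assay, at which 2 of the 4 values shown sit.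

From the compounds shown here alone, whether a simple amine, a morpholine or a carboxylic acid on this aromatic carbon would read nearer compound 1 or compound 4 stays open. So does whether a shorter chain carrying the diazepane would do the same.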